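Methyl in place of nitro on the benzylsulfanyl arm

The source may hold more compounds than are shown below. What is called first, only, known or untested is meant among the compounds shown, and "the series" means these compounds.

Among the compounds with values here, compound 3 `Cc1cc(Nc2cc(-c3ccccc3)[nH]n2)n2nc(SCc3ccc([N+](=O)[O-])cc3)nc2n1` stands at the highest of the three numbers so far in a functional assay on MCF7 cells (Homo sapiens) for inhibition, read by MTT assay, with a stated time of 72 h; on this read-out higher numbers stand for weaker inhibition and lower numbers for stronger inhibition: compound 3 gives 5060 nM, while compound 2 `Cc1cc(Nc2ccn(Cc3cccc4ccccc34)n2)n2nc(SCc3ccc(Br)cc3)nc2n1` gives 4310 nM and compound 1 `Cc1cc(Nc2cc(-c3ccccc3)[nH]n2)n2nc(SCCCc3ccccc3)nc2n1` gives 3900 nM; all three lie within the scatter of one another, so no order among them can be read. Compound 4 `Cc1ccc(CSc2nc3nc(C)cc(Nc4cc(-c5ccccc5)[nH]n4)n3n2)cc1` differs from compound 3 by methyl in place of nitro on an aromatic carbon. Within the data shown here, the only measured step on this sulfur-bound chain, a 1.3-fold higher number from compound 1 to compound 3 (0.11 log units; within the scatter), stayed within the scatter, and no measured step bears on a change at that aromatic carbon itself. The step of a 1.1-fold lower number from compound 3 to compound 4 (0.05 log units; within the scatter) is therefore expected to stay within the scatter. Compound 4 is estimated at 4500 nM, with a range from 1800 nM to 11000 nM.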

Compound 4, half-maximal inhibitory concentration: 7290 nM
For compound 4 the middle estimate is 1.6-fold (0.21 log units) below the measured one; measured number inside the range.
By their numbers in this assay, from the lowest: compounds 1, 2, 3 and 4 (each within the scatter of the next).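

In this assay, within the data shown here, the first measured change at this aromatic carbon, a 1.4-fold higher number from compound 3 to compound 4 (0.16 log units; within the scatter), shows that replacing nitro, a group with hydrogen-bond acceptors, by methyl, which has none, gives no readable shift. The 4-methylphenyl for phenethyl change on the sulfur-bound chain, a 1.9-fold higher number from compound 1 to compound 4 (0.27 log units; within the scatter), also gives no readable shift. Nothing measured here bears on why these numbers fall as they do.

On these data alone, whether an amine or a carboxylic acid on that aromatic carbon would give a step beyond the scatter remains open. The same holds for a longer chain on the sulfur.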